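The compounds below may be only part of what the source reports. "The series", "measured", "known", "first", "only" and "open" are said of these compounds alone.

Of the compounds shown here, three sharing one core have been measured in an assay on cells for inhibition of Indoleamine 2,3-dioxygenase 1 (Homo sapiens); a lower number here means a stronger inhibitor, a higher number a weaker inhibitor. Compound 1 `CC(C)CSc1nnc2scc(-c3ccc(Cl)cc3)n12` gives 256 nM. Compound 2 `Cc1ccc(CS(=O)(=O)NCc2cnc3scc(-c4ccc(Br)cc4)n23)cc1` gives 855 nM in this assay. Compound 3 `N#Cc1ccc(NC(=O)NCc2cnc3scc(C#Cc4cccnc4)n23)cc1` gives 3200 nM in this assay, the highest of the three numbers, and its gap to each of the other two lies beyond the usual scatter of repeated measurements, so compound 3 is the weakest inhibitor seen so far.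

Compound 4 `N#Cc1ccc(NC(=O)NCc2cnc3scc(C#CC4CC4)n23)cc1` has not yet been measured. It differs from compound 3 in a single place: cyclopropyl in place of pyridin-3-yl on a triple-bonded carbon. The rest of the molecule is unchanged. Among the compounds with values here, no pair of measured compounds differs by this kind of swap, so there is no measured step to lean on, and the three measured values do not show how such a swap behaves. The expected step in this assay is a 1.3-fold higher number from compound 3 to compound 4 (0.10 log units; within the scatter), a shift small enough that it is not expected to reach beyond the scatter. Compound 4 is therefore estimated at 4000 nM, with a likely range from 1500 nM to 12000 nM.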

Compound 4, half-maximal inhibitory concentration: 102 nM
For compound 4 the middle estimate is 39-fold (1.59 log units) above the measured one, outside the stated range (below it).
By their numbers in this assay, from the lowest: compound 4; then compound 1; then compound 2; then compound 3.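

In this assay, within the data shown here, the group on the triple-bonded carbon turns out to matter a great deal: the swap of pyridin-3-yl for cyclopropyl gives a 31-fold lower number from compound 3 to compound 4 (1.50 log units; beyond the scatter), the first measured step at this position, and one well beyond the scatter. The earlier compounds shown here could not show this, since no two of them differed in only one place. The change takes away a six-membered aromatic ring carrying a nitrogen and a hydrogen-bond acceptor, and the three-membered ring of carbon only that replaces it is not merely tolerated but gives a far lower number.

On these data alone, whether this depends on the cyclopropyl ring itself stays open, and a cyclobutyl ring, a straight propyl chain or a simple amine on the same carbon would test it. Nothing measured here explains the size of this step.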